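The compounds below may be only part of what the source reports. "The series", "measured", "known", "first", "only" and "open" are said of these compounds alone.

Compound 1 `C=C1C(=O)[C@H]2C[C@]1(O)CC1=C2[C@]2(C)CCCC(C)(C)[C@H]2CC1`: 2200 nM
Compound 2 `C[C@@H]1C(=O)[C@H]2C[C@]1(O)CC1=C2[C@]2(C)CCC[C@](C)(CO)[C@H]2CC1`: > 50000 nM
Compound 3 `C[C@@H]1C(=O)[C@H]2C[C@]1(O)CC1=C2[C@]2(C)CCCC(C)(C)[C@H]2CC1`: > 50000 nM

In a functional assay on K562 cells (Homo sapiens) for cytotoxicity, read by MTT assay, with a stated time of 24 h (on this read-out higher numbers stand for weaker inhibition and lower numbers for stronger inhibition), compound 1 gives 2200 nM. Compound 2 reaches only the limit of the measurement, > 50000 nM. Compound 3 likewise stops at that limit, > 50000 nM. Compound 2 thus stands at the edge of the numbers shown, where no exact value is reported. Within the data shown here, the single step available, a step that the two limits leave unreadable from compound 2 to compound 3, is unreadable: both of its ends are limits. Compound 4 `C[C@@H]1C(=O)[C@H]2C[C@]1(O)CC1=C2[C@]2(C)CCC[C@](C)(C=O)[C@H]2CC1` arises from compound 2 through (formyl in place of hydroxymethyl on a saturated ring carbon). Among the measured compounds shown here, no measured step covers a formyl group, so the direction of this change is unknown. Given (the limit of > 50000 nM in this assay, at which 2 of the 3 values shown sit), compound 4 is expected to stay near that limit, a step of a number no higher from compound 2 to compound 4 (the limit leaves the size open). The estimate for compound 4 is 50000 nM, ranging from 15000 nM to 150000 nM.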

Compound 4, half-maximal inhibitory concentration: > 50000 nM
Compound 4: a limit, no number; the forecaster's own chance of this, stated with the estimate: 70%; the middle value sits exactly at the limit.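

No new step can be read between compound 2 and compound 4, as both values in this assay are limits and not numbers. The compounds shown leave open whether formyl in place of hydroxymethyl changes cytotoxicity at all.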